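The compounds below may be only part of what the source reports. "The series", "measured", "known", "first", "only" and "open" are said of these compounds alone.

Three compounds share one core and differ only in the group on an amide-type nitrogen in a ring. All three were tested in a functional assay on A549 cells (Homo sapiens) for antiproliferative activity, read by MTT assay, with a stated time of 72 h; on this read-out lower numbers stand for stronger inhibition and higher numbers for weaker inhibition. Compound 1 `COc1cccc(N2C(=O)COc3ccc(-c4cnc(OC)c(NS(=O)(=O)c5ccc(F)cc5)c4)cc32)c1`, with 3-methoxyphenyl, gives 11200 nM. Compound 2 `COc1ncc(-c2ccc3c(c2)N(C2CC2)C(=O)CO3)cc1NS(=O)(=O)c1ccc(F)cc1`, with cyclopropyl, gives 3320 nM. Compound 3 `COc1ccc(N2C(=O)COc3ccc(-c4cnc(OC)c(NS(=O)(=O)c5ccc(F)cc5)c4)cc32)cc1`, with 4-methoxyphenyl, gives 1350 nM, the lowest of the three numbers.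

The next change, (isopropyl in place of 4-methoxyphenyl on an amide-type nitrogen in a ring), leads to compound 4 `COc1ncc(-c2ccc3c(c2)N(C(C)C)C(=O)CO3)cc1NS(=O)(=O)c1ccc(F)cc1`. Like cyclopropyl, isopropyl has no aromatic ring, so the closest guide is a 2.5-fold lower number from compound 2 to compound 3 (0.39 log units; beyond the scatter), a modest step that would be reversed here. The comparison is imperfect, as a 3.4-fold lower number from compound 1 to compound 2 (0.53 log units; beyond the scatter) shows that swapping an aryl group for cyclopropyl can also lower the number. The other measured step, an 8.3-fold lower number from compound 1 to compound 3 (0.92 log units; beyond the scatter), shows how much the series can move with this one group.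

A modest rise in this assay is therefore expected, and the estimated step is a 2.6-fold higher number from compound 3 to compound 4 (0.41 log units; beyond the scatter). For compound 4 the expected value is 3500 nM, within an estimated range of 1300 nM to 9500 nM.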

Compound 4, half-maximal inhibitory concentration: 4920 nM
Estimate against measurement, compound 4: 1.4-fold (0.15 log units) below; the measured number falls inside the stated range.
By their numbers in this assay, from the lowest: compound 3; then compounds 2 and 4 (each within the scatter of the next); then compound 1.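

In this assay, isopropyl and cyclopropyl, the two groups here without an aromatic ring, cannot be told apart, with a 1.5-fold higher number from compound 2 to compound 4 (0.17 log units; within the scatter). The two methoxyphenyl groups fall on opposite sides of this pair, with a 3.6-fold higher number from compound 3 to compound 4 (0.56 log units; beyond the scatter) but also a 2.3-fold lower number from compound 1 to compound 4 (0.36 log units; beyond the scatter), so among these compounds an aromatic ring on this nitrogen does not by itself set the direction of the change, and replacing it with isopropyl can raise or lower the number. No measurement available here explains these differences.

The compounds shown leave open how a plain phenyl, a longer chain such as butyl, or a chain ending in an amine would behave on this nitrogen. They also leave open whether 3-chlorophenyl and 4-chlorophenyl would differ as the two methoxyphenyl groups do.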